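Furan Replaces Naphthalene on a Cytotoxicity-Limited Scaffold

The source may hold more compounds than are shown below. What is called first, only, known or untested is meant among the compounds shown, and "the series" means these compounds.

Compound 1 `CC(C)N(Cc1cccc(OCCCCCC(=O)O)c1)C(=O)c1ccc(-c2ccc3cc[nH]c3c2)cc1` and compound 2 `CCOC(=O)CCCCCOc1cccc(CN(C(=O)c2ccc(-c3ccc4ccccc4c3)cc2)C(C)C)c1` share an amide-bearing core with an aryl group at one end, and both were examined in an ADME assay on BJ cells (Homo sapiens) for cytotoxicity, read by CellTiter-Glo and resazurin assay, with a stated time of 72 h; on this read-out lower numbers stand for an effect already at smaller amounts and higher numbers for an effect only at larger amounts of compound. In this assay compound 1 gives > 26000 nM, which is a limit of the assay rather than a number. In this assay compound 2 likewise gives > 26000 nM, again only a limit. For the measured compounds named here, compound 2 therefore stands where every measured value sits, at the limit of > 26000 nM in this assay, at which 2 of the 2 values shown sit; no measured compound yields an actual number. Compound 3 `CCOC(=O)CCCCCOc1cccc(CN(C(=O)c2ccc(-c3ccoc3)cc2)C(C)C)c1` has not yet been measured. It differs from compound 2 by furan-3-yl in place of naphthalen-2-yl on an aromatic carbon. Going by the values given here, with both measured compounds at the limit, no measured step exists from which a direction could be read. Compound 3 is expected to remain at or near the limit, and the step that the limit leaves unreadable from compound 2 to compound 3 is expected to be none beyond the scatter. The estimate for compound 3 is 30000 nM, with a range from 18000 nM to 60000 nM.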

Compound 3, half-maximal effective concentration: > 26000 nM
Compound 3 ended at the assay's limit; the forecaster's own chance of this, stated with the estimate: 85%; the middle value does not contradict the limit.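

With compound 3 also a limit of this assay at > 26000 nM, no step can be read from compound 2 to compound 3: the limit of > 26000 nM in this assay, at which 3 of the 3 values shown sit. The compounds shown leave open whether furan-3-yl and naphthalen-2-yl differ at all on this read-out, since none yields an actual number.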